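This account rests on a few compounds, and the source may have more. Where it says the series, first, only, none or still open, it means among the compounds named here.

In a functional assay on CHO cells for agonist activity at Alpha-1A adrenergic receptor (Homo sapiens), read by fluorescence and calcium flux (on this read-out lower numbers stand for an effect already at smaller amounts and higher numbers for an effect only at larger amounts of compound), three compounds of a shared core have been measured. Compound 1 `CS(=O)(=O)Cc1cccc2c1CCC2c1ncc[nH]1` gives 84 nM. Compound 2 `COCc1ccc(F)c2c1CCC2c1ncc[nH]1` gives 658 nM. Compound 3 `c1cc(Cn2cccn2)c2c(c1)[C@H](c1ncc[nH]1)CC2` gives 32 nM. Among these three numbers compound 1 holds the second highest place: its nearest neighbour is compound 3, whose lower number lies beyond the usual scatter, and its furthest is compound 2, whose higher number also lies beyond the scatter.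

The next compound, compound 4 `c1cc(Cn2ccnn2)c2c(c1)C(c1ncc[nH]1)CC2`, has not yet been measured in this assay. It differs from compound 1 in one place: 1H-1,2,3-triazol-1-yl in place of methylsulfonyl on a saturated chain carbon bound to an aromatic carbon. Within the data shown here, no measured pair in this set shows this exact exchange, so the size of the step must be judged from what stands nearby. Compound 3 carries a closely related five-membered aromatic ring on the same kind of saturated chain carbon and gives 32 nM, a number beyond the scatter below that of compound 1. On that basis the step from compound 1 to compound 4 is expected to run toward lower numbers, by a 1.9-fold lower number from compound 1 to compound 4 (0.27 log units; within the scatter). Compound 4 is therefore estimated at 45 nM, with a likely range from 15 nM to 140 nM.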

Compound 4, half-maximal effective concentration: 90 nM
Compound 4: the middle estimate sits 2.0-fold (0.30 log units) below what was measured; the measured number falls inside the stated range.
By their numbers in this assay, from the lowest: compound 3; then compounds 1 and 4 (each within the scatter of the next); then compound 2.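

In this assay, among these compounds, putting 1H-1,2,3-triazol-1-yl in place of methylsulfonyl gives a 1.1-fold higher number from compound 1 to compound 4 (0.03 log units; within the scatter), the first direct reading of an exchange at this place, and the two groups cannot be told apart on this read-out. The exchange is not a small one on paper: a group with no ring and two double bonds outside aromatic rings gives way to a five-membered aromatic ring with three hetero atoms, so on this core the saturated chain carbon bound to an aromatic carbon can carry either group with no difference beyond the scatter. Nothing available here accounts for why two such different groups read alike.

This single pair leaves open whether a carboxylic acid or a primary amine on the same chain carbon would also read like these two groups, and whether a longer chain carrying the 1H-1,2,3-triazol-1-yl group would do the same. It also leaves open whether this exchange would read alike on the fluorine-bearing core of compound 2.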